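Thiophene to trifluoromethylphenyl on the shared core

This account rests on a few compounds, and the source may have more. Where it says the series, first, only, none or still open, it means among the compounds named here.

Compound 1 `Brc1cn2ccnc2c(-c2ccc3ncn(C4CCCCC4)c3c2)n1` gives 37.6% in a functional assay on UO-31 cells (Homo sapiens) for inhibition, read by sulforhodamine B assay, with a stated time of 48 h, tested at 10 uM; a higher number here means more inhibition at the concentration tested (going by the name of the read-out), a lower number less inhibition. Compound 2 `COc1ccc(-c2cn3ccnc3c(-c3ccc4ncn(C5CCCCC5)c4c3)n2)cc1` gives 61.5% in this assay, and compound 3 `c1csc(-c2cn3ccnc3c(-c3ccc4ncn(C5CCCCC5)c4c3)n2)c1` gives 10.9%. Compound 3 therefore stands lowest of the three: the steps of a number 26.7 percentage points lower from compound 1 to compound 3 (beyond the scatter) and a number 50.6 percentage points lower from compound 2 to compound 3 (beyond the scatter) both run downward into it. Compound 4 `FC(F)(F)c1cccc(-c2cn3ccnc3c(-c3ccc4ncn(C5CCCCC5)c4c3)n2)c1` differs from compound 3 as 3-(trifluoromethyl)phenyl in place of thiophen-2-yl on an aromatic carbon. The step that bears most on this change is a number 50.6 percentage points lower from compound 2 to compound 3 (beyond the scatter), which puts a six-membered carbon ring well above the thiophene on the same aromatic carbon; a number 23.9 percentage points higher from compound 1 to compound 2 (beyond the scatter) likewise puts that aryl above bromo. Compound 4 is accordingly expected to rise, an estimated step of a number 34.1 percentage points higher from compound 3 to compound 4 (beyond the scatter). The estimate for compound 4 is 45%, with a range of 15% to 75%.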

Compound 4, a percentage reported as inhibition, at one concentration (the size of the read-out at that concentration, not a potency): 22.5%
For compound 4 the middle estimate is 22.5 percentage points above the measured one; low and high end bracket the measured number.
By their numbers in this assay, from the lowest: compound 3; then compound 4; then compound 1; then compound 2.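

In this assay an aryl ring at this aromatic carbon does not by itself keep the read-out high: a number 39 percentage points lower from compound 2 to compound 4 (beyond the scatter) and so the two substituted phenyl groups differ widely, while a number 15.1 percentage points lower from compound 1 to compound 4 (beyond the scatter) and this aryl falls under bromo, unlike 4-methoxyphenyl. Replacing thiophen-2-yl gives only a modest gain, a number 11.6 percentage points higher from compound 3 to compound 4 (beyond the scatter) and compound 3 remains lowest.

Open, as far as these compounds go, is whether the gap between compound 2 and compound 4 follows the substituent or its ring place, and how a phenyl ring carrying an amine or a carboxylic acid would read here. Nothing available accounts for these differences.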